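The source may report more compounds than this note shows. Statements on the series, on what has been measured and on what is new or still open speak of the compounds shown alone.

Compound 3 `CCCCS(=O)(=O)Oc1ccc(/C=C/C(=O)Nc2ccccc2C)cc1OC` stands second highest of three in a toxicity assay on L02 cells (Homo sapiens) for cytotoxicity, read by MTT assay, with a stated time of 24 h; on this read-out lower numbers stand for higher toxicity in this test and higher numbers for lower toxicity in this test: compound 3 gives 56100 nM, close to compound 2 `CCCCS(=O)(=O)Oc1ccc(/C=C/C(=O)Nc2ccc(CC)cc2)cc1OC`, which gives 89000 nM, and far from compound 1 `CCCCS(=O)(=O)Oc1ccc(/C=C/C(=O)Nc2ccccc2)cc1OC`, which gives 3320 nM. The steps of a 27-fold higher number from compound 1 to compound 2 (1.43 log units; beyond the scatter) and a 17-fold higher number from compound 1 to compound 3 (1.23 log units; beyond the scatter) were large, while a 1.6-fold lower number from compound 2 to compound 3 (0.20 log units; within the scatter) stayed within the scatter. Compound 4 `CCCCS(=O)(=O)Oc1ccc(/C=C/C(=O)OC)cc1OC` arises from compound 3 by methoxy in place of (2-methylphenyl)amino on a carbonyl carbon. Among the measured compounds shown here, no measured step touches the amide-type nitrogen or the carbonyl carbon itself, so none bears directly on this change, and the direction in this assay is therefore open. The estimate for compound 4 in this assay is 25000 nM, within 4000 nM to 150000 nM, which would mean an expected step of a 2.2-fold lower number from compound 3 to compound 4 (0.35 log units; beyond the scatter).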

Compound 4, half-maximal cytotoxic concentration: 208000 nM
Estimate against measurement, compound 4: 8.3-fold (0.92 log units) below; measured number outside the range, above it.
By their numbers in this assay, from the lowest: compound 1; then compounds 3 and 2 (each within the scatter of the next); then compound 4.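

In this assay, methoxy on the carbonyl carbon in place of each aryl amino group moves the number the same way, with a 3.7-fold higher number from compound 3 to compound 4 (0.57 log units; beyond the scatter) and a 2.3-fold higher number from compound 2 to compound 4 (0.37 log units; beyond the scatter) and also a 63-fold higher number from compound 1 to compound 4 (1.80 log units; beyond the scatter) as the three steps. So none of the three aryl amino groups is needed for the number to rise, and the largest step starts from the anilino compound. Nothing measured here explains this result. The compounds shown leave open how a carboxylic acid, a longer alkoxy chain or a simple alkylamino group on that carbonyl carbon would read in this test.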